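The compounds below may be only part of what the source reports. "The series", "measured", "known", "first", "only" and "open" are said of these compounds alone.

Series notes. Two compounds of this series have been run so far in a functional assay on 786-0 cells (Homo sapiens) for antiproliferative activity, with a stated time of 48 h; on this read-out lower numbers stand for stronger inhibition of growth and higher numbers for weaker inhibition of growth. Compound 1 `Cc1cc(O)c(C2=NN(c3ccc(S(N)(=O)=O)cc3)C(c3ccccc3O)C2)cc1Cl` gives 2230 nM. Compound 2 `Cc1cc(O)c(C2=NN(c3ccc(S(N)(=O)=O)cc3)C(/C=C/c3ccccc3)C2)cc1Cl` gives 4090 nM. Within the data shown here, compound 2 stands with the highest of the two numbers, and its nearest neighbour is compound 1; the only measured step here, a 1.8-fold higher number from compound 1 to compound 2 (0.26 log units; within the scatter), swaps 2-hydroxyphenyl for 2-phenylethenyl on a saturated ring carbon and stays within the scatter.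

Compound 3 `COc1ccc(C2CC(c3cc(Cl)c(C)cc3O)=NN2c2ccc(S(N)(=O)=O)cc2)cc1OC` is not yet measured. Its change from compound 2 is 3,4-dimethoxyphenyl in place of 2-phenylethenyl on a saturated ring carbon. Among the measured compounds shown here, no measured step covers 3,4-dimethoxyphenyl at this position; the one step at this carbon, from compound 1 to compound 2, is within the scatter, so the return of a six-membered aromatic ring at the saturated ring carbon gives no ground to expect a move beyond the scatter in this assay in either direction. Compound 3 is therefore estimated at 2600 nM, with a range of 1000 nM to 6500 nM, which is expected to mean a step of a 1.6-fold lower number from compound 2 to compound 3 (0.20 log units; within the scatter).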

Compound 3, concentration for 50% growth inhibition: 2370 nM
Estimate against measurement, compound 3: 1.1-fold (0.04 log units) above; measured number inside the range.
By their numbers in this assay, from the lowest: compounds 1, 3 and 2 (each within the scatter of the next).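

In this assay, placing 3,4-dimethoxyphenyl on the saturated ring carbon gives a 1.7-fold lower number from compound 2 to compound 3 (0.24 log units; within the scatter) and a 1.1-fold higher number from compound 1 to compound 3 (0.03 log units; within the scatter) so the position now has a third group with no step beyond the scatter. This extends the earlier single comparison: hydrogen-bond acceptors enter where 2-phenylethenyl has none, and the read-out stays within the scatter, as it does with 2-hydroxyphenyl on the same carbon. No supporting data are available to account for this lack of separation among the three groups.

On these data alone, it remains open whether an amine, a carboxylic acid or a longer alkyl chain at this carbon would produce a step beyond the scatter. The contribution of the 4-sulfamoylphenyl and 5-chloro-2-hydroxy-4-methylphenyl groups also remains open, as both are constant across the compounds shown.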